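The source may report more compounds than this note shows. Statements on the series, on what has been measured and on what is new or still open speak of the compounds shown alone.

In a functional assay on MCF7 cells (Homo sapiens) for cytotoxicity, read by MTT assay, with a stated time of 72 h (a higher number here means a weaker inhibitor, a lower number a stronger inhibitor), compound 1 `O=C(CSC(=S)N[C@H]1CCOC1=O)Nc1ccc(Br)cc1` gives 66500 nM, the highest of the three numbers recorded. Compound 2 `O=C(CCl)Nc1ccc(C(=O)/C=C/c2ccc(Cl)cc2)cc1` gives 4100 nM and compound 3 `O=C(CCl)Nc1ccc(C(=O)/C=C/c2ccc(Br)cc2)cc1` gives 4640 nM. Within the data shown here, the only measured step, a 1.1-fold higher number from compound 2 to compound 3 (0.05 log units; within the scatter), does not touch the change at hand. Compound 4 `O=C(CSC(=S)N[C@H]1CCOC1=O)Nc1ccc(C(=O)/C=C/c2ccccc2)cc1` differs from compound 1 by (2-phenylethenyl)carbonyl in place of bromo on an aromatic carbon. Among the measured compounds shown here, no measured pair carries this exact change, so the expectation rests on compound 2 and compound 3, which carry a related (2-phenylethenyl)carbonyl group on a different chain and give far lower numbers than compound 1. A lower number is therefore expected for compound 4, with an estimated step of a 4.4-fold lower number from compound 1 to compound 4 (0.65 log units; beyond the scatter). Compound 4 is estimated at 15000 nM, with a range from 4000 nM to 55000 nM.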

Compound 4, half-maximal inhibitory concentration: 44300 nM
Beside the measured number, compound 4's estimate is 3.0-fold (0.47 log units) below it; low and high end bracket the measured number.
By their numbers in this assay, from the lowest: compounds 2 and 3 (each within the scatter of the next); then compounds 4 and 1 (each within the scatter of the next).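

In this assay, putting (2-phenylethenyl)carbonyl in place of bromo on this aromatic carbon, para to a large group, gives a 1.5-fold lower number from compound 1 to compound 4 (0.18 log units; within the scatter). Among these compounds, this is the first step measured at this position, and it shows that 10 heavy atoms and a further aromatic ring can replace a single bromine without moving the number beyond the scatter. No measurement shown here explains this result. Still open, going by these compounds, is whether an amine or a carboxylic acid at this position would shift the number beyond the scatter.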